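A few compounds are considered here, and "the series" means these few. Any claim that something is new, unique, unknown or untested is made for them only; others in the source may bear on it.

In a functional assay on MIA PaCa-2 cells (Homo sapiens) for inhibition, read by MTT assay, with a stated time of 72 h (a higher number here means a weaker inhibitor, a lower number a stronger inhibitor), compound 1 (`COc1cc(NC(C)CCCNC(=O)Nc2cccc(Cl)c2)c2ncccc2c1`) gives 21000 nM and compound 2 (`COc1cc(NC(C)CCCNC(=O)Nc2ccc(F)cc2)c2ncccc2c1`) gives 21000 nM. Among the compounds with values here, these two share the highest number of the three measured so far, while compound 3 (`COc1cc(NC(C)CCCNC(=O)Nc2cc(C(F)(F)F)cc(C(F)(F)F)c2)c2ncccc2c1`) gives a lower 4700 nM. Compound 4 (`COc1cc(NC(C)CCCNC(=O)NNC(=O)Nc2cccc(Cl)c2)c2ncccc2c1`) departs from compound 2 with ((3-chlorophenyl)carbamoyl)amino in place of 4-fluorophenyl on an amide-type nitrogen. Within the data shown here, the one measured step that bears on this change is no change at the digits printed from compound 1 to compound 2 (within the scatter), which lies within the scatter and shows that swapping 3-chlorophenyl for 4-fluorophenyl leaves the number unmoved. Among the measured compounds shown here, that step tests only part of the change, since no measured compound carries the ((3-chlorophenyl)carbamoyl)amino group. No step beyond the scatter is therefore expected in this assay, in either direction, although the uncertainty is wide. The expected step is a 1.4-fold lower number from compound 2 to compound 4 (0.15 log units; within the scatter). For compound 4 the estimated value is 15000 nM, with an expected range from 5000 nM to 45000 nM.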

Compound 4, half-maximal inhibitory concentration: 74000 nM
Compound 4: the middle estimate sits 4.9-fold (0.69 log units) below what was measured; the whole stated range lies below it.
By their numbers in this assay, from the lowest: compound 3; then compounds 1 and 2 (each within the scatter of the next); then compound 4.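

Compound 4 shows that this position, on an amide-type nitrogen whose other neighbour is a carbonyl carbon, does not accept every change without effect in this assay: ((3-chlorophenyl)carbamoyl)amino in place of 3-chlorophenyl gives a 3.5-fold higher number from compound 1 to compound 4 (0.55 log units; beyond the scatter), and in place of 4-fluorophenyl it gives a 3.5-fold higher number from compound 2 to compound 4 (0.55 log units; beyond the scatter). The 3-chlorophenyl ring is present in both compound 1 and compound 4, so the first of these steps reflects the added carbamoyl-amino link, and it leaves compound 4 the weaker inhibitor. Nothing measured here explains this step.

From the compounds shown here alone, it remains open whether a link built from a methylene or an ether oxygen would give the same result. Going by these compounds, it is also open whether the two trifluoromethyl groups of compound 3 would keep their lower number on the carbamoyl-amino link.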